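The source may report more compounds than this note shows. Statements on the series, on what has been measured and on what is new or still open speak of the compounds shown alone.

Three carbamates built on the same core were tested in an assay on HEK293 cells for inhibition of N-acylethanolamine-hydrolyzing acid amidase (Homo sapiens), read by fluorescence, with stated times of 10 min and 50 min; a lower number here means a stronger inhibitor, a higher number a weaker inhibitor. Compound 1 `O=C(N[C@H]1CNC1=O)OCc1ccc2c(c1)CCC2` gives 130 nM in this assay, and compound 3 `O=C(N[C@H]1CNC1=O)OCCCCCc1ccccc1` gives 298 nM. Compound 2 `O=C(N[C@H]1CNC1=O)OCc1ccc(C2CCOCC2)cc1` gives 1370 nM, the highest number of the three; its gap to compound 3 and its wider gap to compound 1 both lie beyond the usual scatter of this assay, so compound 2 is the weakest inhibitor among the measured compounds.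

Compound 4 `O=C(N[C@H]1CNC1=O)OCc1ccc(-c2ccccc2)cc1` differs from compound 2 in one place: phenyl in place of oxan-4-yl on an aromatic carbon. For the measured compounds named here, no measured pair in this set shows that exact exchange, so the size of the step can only be estimated. Going by these compounds, the two compounds whose side chains are built from carbon only, compound 1 with 130 nM and compound 3 with 298 nM, both sit well below compound 2, which suggests that a carbon-only ring in place of the oxan-4-yl group is more likely to lower the number than to raise it, though by how much remains open.

The expected step of a 3.9-fold lower number from compound 2 to compound 4 (0.59 log units; beyond the scatter) is therefore towards a stronger inhibitor, beyond the scatter. Compound 4 is estimated at 350 nM, with a range from 100 nM to 1200 nM.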

Compound 4, half-maximal inhibitory concentration: 513 nM
The estimate for compound 4 lay 1.5-fold (0.17 log units) below the measured number, within the range that was stated.
By their numbers in this assay, from the lowest: compound 1; then compounds 3 and 4 (each within the scatter of the next); then compound 2.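

In this assay, for the compounds shown here, phenyl in place of oxan-4-yl on an aromatic carbon, para to a large group, gives a 2.7-fold lower number from compound 2 to compound 4 (0.43 log units; beyond the scatter); this is the only step in the set where a single place changes, so it is the first direct reading of this position, and it is modest. Both groups have 6 heavy atoms, so the exchange keeps that count while replacing a non-aromatic ring with 1 oxygen and 1 hydrogen-bond acceptor by an aromatic ring of carbon only, and these changes arrive together, so the step cannot assign the shift to any one of them. Nothing available bears on why the number moves in this direction.

The compounds shown leave open whether cyclohexyl at the same place, a carbon-only ring that is not aromatic, would stand with phenyl or with oxan-4-yl, which would separate the loss of the ring oxygen from the gain of the aromatic ring. They also leave open how an amine such as piperidin-4-yl, or a carboxylic acid on the added phenyl, would move the number here.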